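The source may hold more compounds than are shown below. What is called first, only, known or untested is meant among the compounds shown, and "the series" means these compounds.

In a physicochemical assay for solubility (on this read-out higher numbers stand for higher solubility and lower numbers for lower solubility), compound 1 `CNC(=O)c1cc(C(N)=O)cn(Cc2ccccc2)c1=O` gives a true number, 71 ug/mL as measured. Compound 2 `CNC(=O)c1cc(C(=O)NC2CCC2)cn(Cc2cccc(NC)c2)c1=O` stands at >= 155 ug/mL and this is a limit of the assay, not a number. Compound 3 `CNC(=O)c1cc(C(=O)NC2CCC2)cn(Cc2ccccc2)c1=O` has hydrogen in place of methylamino on an aromatic carbon, so 3-(methylamino)benzyl becomes benzyl hydrogen in place of methylamino on an aromatic carbon and nothing else changes. Going by the values given here, a modest fall is expected because compound 1 at 71 ug/mL is the only measured compound with that plain benzyl. The expected change is an at least 1.6-fold lower number from compound 2 to compound 3 (0.21 log units; that floor lies within the scatter) in this assay and no more than moderate. Compound 3 is estimated near 95 ug/mL with 40 ug/mL and 180 ug/mL as the ends of the expected range.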

Compound 3, solubility: 28 ug/mL
Estimate against measurement, compound 3: 3.4-fold (0.53 log units) above, and the stated range ends above it.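

In this assay, going by these compounds alone, hydrogen in place of methylamino on an aromatic carbon gives an at least 5.5-fold lower number from compound 2 to compound 3 (0.74 log units; beyond the scatter), the first direct reading of this position. Cyclobutyl in place of hydrogen on an amide-type nitrogen gives a 2.5-fold lower number from compound 1 to compound 3 (0.40 log units; beyond the scatter), so a second place in the molecule also moves the read-out. Compound 2 stands at a limit of the assay, not a number, so this first step has a floor but no known full size: the limit of >= 155 ug/mL in this assay, at which 1 of the 3 values shown sits.

From the compounds shown here alone, how an amine or a methoxy group on that aromatic carbon would read stays open. So does the effect of a longer chain in place of cyclobutyl.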